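From Compound 3 to Compound 4: Methoxy for Methyl

The source may report more compounds than this note shows. Statements on the series, on what has been measured and on what is new or still open speak of the compounds shown alone.

compound 1 `COc1ccc(C(=O)CSC(=S)Nc2cc(OC)c(OC)c(OC)c2)cc1`: 18.6 ug/mL in a functional assay on MCF7 cells (Homo sapiens) for cytotoxicity, read by MTT assay, with a stated time of 48 h; a lower number here means a stronger inhibitor, a higher number a weaker inhibitor
compound 2 `COc1cc(N2C(=S)SCC2(O)c2ccc(Cl)cc2Cl)cc(OC)c1OC`: 9.6 ug/mL
compound 3 `COc1cc(-n2c(-c3ccc(C)cc3)csc2=S)cc(OC)c1OC`: 19.7 ug/mL

Among these three numbers compound 3 stands at the highest. Its nearest neighbour is compound 1, and the gap between the two lies within the usual scatter of this assay, so the values of compound 3 and compound 1 cannot be told apart. The gap from compound 3 down to compound 2 lies beyond the scatter; the two values simply differ, and nothing more can be said of that pair here.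

Compound 4 `COc1ccc(-c2csc(=S)n2-c2cc(OC)c(OC)c(OC)c2)cc1` is not yet measured. It differs from compound 3 in one place: methoxy in place of methyl on an aromatic carbon. Among the measured compounds shown here, no pair among the three measured compounds shows this change, so the data give no measured step to lean on. The step from compound 3 to compound 4 in this assay is therefore expected to be small, a 1.1-fold lower number from compound 3 to compound 4 (0.04 log units; within the scatter), with no direction beyond the scatter. Compound 4 is estimated at 18 ug/mL, with a range from 9 ug/mL to 36 ug/mL.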

Compound 4, half-maximal inhibitory concentration: > 100 ug/mL
Compound 4 was reported as a limit; the forecaster's own chance of this, stated with the estimate: 10%; at least 5.5-fold (0.74 log units) between middle value and limit.
By their numbers in this assay, from the lowest: compounds 2, 1 and 3 (each within the scatter of the next, the first and the last beyond it). At a limit, above all of these: compound 4.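

Until this pair, nothing spoke to this position. The change from 4-methylphenyl to 4-methoxyphenyl, on an aromatic carbon para to a large group, gives an at least 5.0-fold higher number from compound 3 to compound 4 (0.70 log units; beyond the scatter) in this assay, so this position is not indifferent to the group it carries. The whole difference is one added oxygen, and methyl and methoxy cannot be treated as interchangeable here, even though they count as a small change on paper. The value of compound 4 is a limit and not a number: the limit of > 100 ug/mL in this assay, at which 1 of the 4 values shown sits.

On these data alone, how far compound 4 really lies from compound 3 stays open, as does which feature of methoxy matters, its added oxygen or its added heavy atom. As far as these compounds go, whether an ethyl group, a fluorine atom or an amine at this position would keep the value of compound 3 also stays open.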